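Swapping the Acyl Group of Compound 3

This account rests on a few compounds, and the source may have more. Where it says the series, first, only, none or still open, it means among the compounds named here.

Compound 1 `O=C(Nc1cc(Sc2ncn[nH]2)c(O)c2ccccc12)c1ccc([N+](=O)[O-])cc1`: 37.3%
Compound 2 `O=C(Nc1cc(Sc2ncnc3nc[nH]c23)c(O)c2ccccc12)c1ccc(Cl)cc1`: 21.7%
Compound 3 `O=C(/C=C/c1ccccc1)Nc1cc(Sc2ncn[nH]2)c(O)c2ccccc12`: 26.2%

For the measured compounds named here, in an assay on isolated protein for inhibition of RAC-alpha serine/threonine-protein kinase (Homo sapiens), read by fluorescence, with a stated time of 30 min, tested at 10 uM (a higher number here means more inhibition at the concentration tested (going by the name of the read-out), a lower number less inhibition), compound 3 stands second highest of the three: compound 2 sits within the scatter of it, while compound 1 lies beyond it, and the step of a number 11.1 percentage points lower from compound 1 to compound 3 (beyond the scatter) is the only measured change at the same place. Compound 4 `O=C(Nc1cc(Sc2ncn[nH]2)c(O)c2ccccc12)c1ccc(Cl)cc1` differs from compound 3 in one place: 4-chlorophenyl in place of 2-phenylethenyl on a carbonyl carbon. Going by the values given here, no measured step covers this exchange on the shared core. Compound 2 carries the same 4-chlorophenyl group on another core and gives 21.7%, close to compound 3. Among the compounds with values here, since the one measured step at this place was only modest, compound 4 is expected to move little, a number 1.8 percentage points higher from compound 3 to compound 4 (within the scatter). The estimate for compound 4 is 28%, between 12% and 44%.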

Compound 4, a percentage reported as inhibition, at one concentration (the size of the read-out at that concentration, not a potency): 50.1%
For compound 4 the middle estimate is 22.1 percentage points below the measured one, outside the stated range (above it).
By their numbers in this assay, from the lowest: compounds 2 and 3 (each within the scatter of the next); then compound 1; then compound 4.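

In this assay, for the compounds shown here, the group on the carbonyl carbon matters more than the one earlier step showed: 4-chlorophenyl in place of 2-phenylethenyl gives a number 23.9 percentage points higher from compound 3 to compound 4 (beyond the scatter), and chloro in place of nitro on the aromatic carbon gives a number 12.8 percentage points higher from compound 1 to compound 4 (beyond the scatter). With 4-chlorophenyl held fixed, the group on the sulfur also changes the read-out, the group of 5 heavy atoms in place of the group of 9 giving a number 28.4 percentage points higher from compound 2 to compound 4 (beyond the scatter). No evidence available here explains these steps. From the compounds shown here alone, whether an amine or a carboxylic acid in place of chloro on the aromatic carbon would keep this level of inhibition remains open.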